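The source may hold more compounds than are shown below. What is called first, only, known or untested is meant among the compounds shown, and "the series" means these compounds.

In a functional assay on NCI-H1650 cells (Homo sapiens) for cytotoxicity, read by MTT assay, with a stated time of 72 h (a lower number here means a stronger inhibitor, a higher number a weaker inhibitor), compound 2 `COc1ccc(/C=C2\CN(C)C/C(=C\c3ccc(OC)c(OC)c3)C2=O)cc1OC` gives 9000 nM and compound 1 `CCCN1C/C(=C\c2ccc(OC)c(OC)c2)C(=O)/C(=C/c2ccc(OC)c(OC)c2)C1` gives 16000 nM, so the two values lie within the scatter of each other. Compound 3 `CCN1C/C(=C\c2ccc(OC)c(OC)c2)C(=O)/C(=C/c2ccc(OC)c(OC)c2)C1` differs from compound 2 by a single change, methyl in place of hydrogen on a saturated chain carbon bound to an amine nitrogen in a ring, which also reads as methyl to ethyl. Going by the values given here, only one measured step bears on this place, and it replaces ethyl with hydrogen: a 1.8-fold lower number from compound 1 to compound 2 (0.25 log units; within the scatter). That step stays within the scatter, and compound 3 adds a smaller piece of chain to compound 2 than the ethyl removed in it. No step beyond the scatter is therefore expected in this assay, with at most a slight shift towards a higher number. The expected size is a 1.3-fold higher number from compound 2 to compound 3 (0.12 log units; within the scatter). For compound 3 the estimated value is 12000 nM, with an expected range of 6000 nM to 24000 nM.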

Compound 3, half-maximal inhibitory concentration: 12000 nM
Estimate against measurement, compound 3: no gap at the digits printed; low and high end bracket the measured number.
By their numbers in this assay, from the lowest: compounds 2, 3 and 1 (each within the scatter of the next).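

In this assay the methyl to ethyl change gives a 1.3-fold higher number from compound 2 to compound 3 (0.12 log units; within the scatter), and the further step along the same chain gives a 1.3-fold lower number from compound 1 to compound 3 (0.12 log units; within the scatter). Going by these compounds alone, the earlier pair showed only one wider step at this place, on a saturated chain carbon bound to an amine nitrogen in a ring, and that step could have hidden a sharper response at an intermediate chain. Compound 3 now fills that gap, and neither of its two single steps leaves the scatter, so across these three compounds the values at this place do not separate.

The compounds shown leave open whether a longer chain, a benzyl group or a carboxylic acid at this place would give a step beyond the scatter. Nothing measured here offers an explanation for these values.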